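A few compounds are considered here, and "the series" means these few. Any claim that something is new, unique, unknown or untested is made for them only; others in the source may bear on it.

Compound 1 `COc1ccc(-c2cnc(NC(=O)c3ccc(O)cc3)n2C)cc1` gives > 100000 nM as a limit
Compound 2 `COc1ccc(-c2cnc(NC(=O)c3cccc(O)c3)n2C)cc1` gives > 100000 nM as a limit
Compound 3 `COc1ccc(-c2cnc(NC(=O)C3CCCC3)n2C)cc1` gives > 100000 nM as a limit

In a toxicity assay on THP-1 cells (Homo sapiens) for inhibition (on this read-out higher numbers stand for lower toxicity in this test and lower numbers for higher toxicity in this test), compound 3 stands at a limit and not at a number. For the measured compounds named here, the picture so far is the limit of > 100000 nM in this assay, at which 3 of the 3 values shown sit, and no compound has yet given a true measurement.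

Compound 4 `COc1ccc(-c2cnc(NC(=O)C3CCOCC3)n2C)cc1` has not been measured. It keeps the shared core and carries oxan-4-yl in place of cyclopentyl on a carbonyl carbon, a change that counts out as oxan-4-yl in place of cyclopentyl on a carbonyl carbon and leaves the rest of the structure untouched.

Three measured steps involve the same carbonyl carbon. They are a step that the two limits leave unreadable from compound 1 to compound 2 and a step that the two limits leave unreadable from compound 1 to compound 3 and a step that the two limits leave unreadable from compound 2 to compound 3 and none of them has a size that can be read. Going by the values given here, they show only that all three groups tried there leave the read-out at the limit.

The closest guide is compound 3 with its limit of > 100000 nM and it gives no sign of a change. The expected result is therefore no step beyond the usual scatter in this assay and no direction can be favoured. The estimated change is a number no higher from compound 3 to compound 4 (the limit leaves the size open) and it is expected to be too small to matter. For compound 4 the estimated value is 100000 nM with an expected range from 50000 nM to 200000 nM and a report as a limit is the likeliest outcome.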

Compound 4, half-maximal cytotoxic concentration: > 100000 nM
Compound 4: a limit, no number; the forecaster's own chance of this, stated with the estimate: 85%; the middle value lies on the limit itself.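

The result for compound 4 is a limit, as are those for compound 1, compound 2 and compound 3, so none of the steps to compound 4 can be read in this assay. The picture stays the same: the limit of > 100000 nM in this assay, at which 4 of the 4 values shown sit. The compounds shown leave open whether any group on the carbonyl carbon would give a measured number rather than a limit.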